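The source may hold more compounds than are shown below. What is called first, only, known or untested is meant among the compounds shown, and "the series" means these compounds.

The series shares the core of compound 1 `COc1cc(OC)c2c(=O)cc(-c3ccc(OCCBr)cc3)oc2c1`, and in a functional assay (Homo sapiens) for antiproliferative activity, read by resazurin assay, with a stated time of 48 h, tested at 5 uM (a higher number here means a stronger effect of the compound at the concentration tested, a lower number a weaker effect), compound 1 is reported as "not active" (no number reported), so no single number places it on the scale. Compound 2 `COc1cc(OC)c2c(=O)cc(-c3ccc(OCCCN(C)C)cc3)oc2c1` gives 36% in this assay, and compound 3 `COc1cc(OC)c2c(=O)cc(-c3ccc(OCCN4CCCC4=O)cc3)oc2c1` gives 7%. The one measured step, a number 29 percentage points lower from compound 2 to compound 3 (beyond the scatter), is the only comparison available among these compounds, and it exchanges one nitrogen-bearing group for another at the end of the chain rather than touching the 2-bromoethyl of compound 1. Compound 4 `COc1cc(OC)c2c(=O)cc(-c3ccc(OC4CCNCC4)cc3)oc2c1` differs from compound 1 by piperidin-4-yl in place of 2-bromoethyl on an oxygen on an aromatic ring. Among the measured compounds shown here, no measured step covers this change, so the size and direction of the step from compound 1 to compound 4 cannot be read from the data; the nearest guide is that compound 2, which also carries a nitrogen in the group on the aromatic oxygen, gives 36%, whereas compound 3 gives 7%. Compound 4 is therefore expected to show in this assay an estimated 25%, within a range from 5% to 50%.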

Compound 4, a percentage reported as inhibition, at one concentration (the size of the read-out at that concentration, not a potency): "not active" (no number reported)
For compound 4 the study gives words and no number; there is nothing to compare the estimate with.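

In this assay compound 1 and compound 4 are both reported in words without a number, so no new step can be read between them. The compounds shown leave open how far either lies from compound 2 or compound 3 on this scale. Nothing shown bears on an explanation for this result.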